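Shortening the Branched Carbamate Substituent: Compound 4

The compounds below may be only part of what the source reports. "The series", "measured", "known", "first", "only" and "open" are said of these compounds alone.

Values in a functional assay on MT4 cells (Homo sapiens) for inhibition; on this read-out higher numbers stand for weaker inhibition and lower numbers for stronger inhibition:
compound 1, `CCCCNC(=O)OC/C=C(\C)C1=CC(=O)C(C)(C)O1`, gives 1.2 ug/mL
compound 2, `C/C(=C\COC(=O)Nc1ccccc1)C1=CC(=O)C(C)(C)O1`, gives 103 ug/mL
compound 3, `C/C(=C\COC(=O)NC(C)(C)C)C1=CC(=O)C(C)(C)O1`, gives 2.1 ug/mL

Compound 3 holds the second highest of the three numbers. Its nearest neighbour is compound 1, with the step of a 1.8-fold higher number from compound 1 to compound 3 (0.24 log units; within the scatter) falling within the scatter, whereas the step of a 49-fold lower number from compound 2 to compound 3 (1.69 log units; beyond the scatter) is large and beyond it. The only large movement among the measured compounds therefore comes from swapping the phenyl of compound 2 for an alkyl group; between the two alkyl groups, butyl and tert-butyl, the numbers are indistinguishable.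

Compound 4, `C/C(=C\COC(=O)NC(C)C)C1=CC(=O)C(C)(C)O1`, differs from compound 3 by hydrogen in place of methyl on a saturated chain carbon bound to an amide-type nitrogen and two saturated chain carbons. This is again an alkyl-to-alkyl change on the carbamate nitrogen, and the step that bears on it most directly, a 1.8-fold higher number from compound 1 to compound 3 (0.24 log units; within the scatter), was within the scatter, while the large steps of an 86-fold higher number from compound 1 to compound 2 (1.93 log units; beyond the scatter) and a 49-fold lower number from compound 2 to compound 3 (1.69 log units; beyond the scatter) involve the phenyl compound and do not apply here. Compound 4 is thus expected to show no step beyond the scatter, a 1.2-fold lower number from compound 3 to compound 4 (0.07 log units; within the scatter). The estimated value for compound 4 is 1.8 ug/mL, with a range from 0.7 ug/mL to 5 ug/mL.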

Compound 4, half-maximal inhibitory concentration: 2.3 ug/mL
Compound 4: middle estimate off by 1.3-fold (0.11 log units), on the low side, within the range that was stated.
By their numbers in this assay, from the lowest: compounds 1, 3 and 4 (each within the scatter of the next); then compound 2.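

In this assay, within the data shown here, cutting tert-butyl back to isopropyl gives a 1.1-fold higher number from compound 3 to compound 4 (0.04 log units; within the scatter), which shows for the first time that hydrogen in place of methyl on a saturated chain carbon bound to an amide-type nitrogen and two saturated chain carbons leaves the read-out within the scatter. Isopropyl in place of butyl gives a 1.9-fold higher number from compound 1 to compound 4 (0.28 log units; within the scatter), while isopropyl in place of phenyl gives a 45-fold lower number from compound 2 to compound 4 (1.65 log units; beyond the scatter), so isopropyl joins butyl and tert-butyl as a third alkyl group within the scatter of the others, and among these four compounds only phenyl stands apart. Nothing available explains either the agreement of the alkyl groups or their large separation from phenyl.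

The compounds shown leave open whether a cyclohexyl or a benzyl group on the amide-type nitrogen would read with the alkyl compounds or with the phenyl compound, and whether a longer chain such as octyl would stay in the same range. They also leave open what a bare hydrogen on that nitrogen, with no carbon substituent at all, would give.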